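The source may hold more compounds than are shown below. What is called first, only, known or untested is meant among the compounds shown, and "the series" means these compounds.

Within the data shown here, compound 3 `CC(C)[C@H](NC(=O)COc1cccc2ccccc12)C(=O)N[C@@H](CC(=O)O)C(=O)CSc1nnc(-c2ccccc2)o1` is the one compound here with a measured number: in a functional assay on Jurkat cells (Homo sapiens) for inhibition (on this read-out lower numbers stand for stronger inhibition and higher numbers for weaker inhibition), compound 3 gives 150000 nM. Compound 1 `CC(C)[C@H](NC(=O)COc1cccc2ccccc12)C(=O)N[C@@H](CC(=O)O)C(=O)CSc1ncc[nH]1` reaches only a limit of this assay, > 200000 nM. Compound 2 `CC(C)[C@H](NC(=O)COc1cccc2ccccc12)C(=O)N[C@@H](CC(=O)O)C(=O)CSc1nccn1C` likewise stops at a limit, > 200000 nM. The steps of an at least 1.3-fold lower number from compound 1 to compound 3 (0.12 log units; that floor lies within the scatter) and an at least 1.3-fold lower number from compound 2 to compound 3 (0.12 log units; that floor lies within the scatter) each swap the group on a sulfur, and their floors lie within the scatter. Compound 4 `CC(C)[C@H](NC(=O)COc1cccc2ccccc12)C(=O)N[C@@H](CC(=O)O)C(=O)COc1cc2ccccc2cn1` differs from compound 3 by (isoquinolin-3-yl)oxy in place of (5-phenyl-1,3,4-oxadiazol-2-yl)sulfanyl on a saturated chain carbon bound to a carbonyl carbon. The two measured steps touch the same place but yield only floors, so this assay gives no ground to expect a change beyond the scatter. Compound 4 is therefore expected to give 150000 nM, estimated between 30000 nM and 200000 nM. The expected step is no change at the digits printed from compound 3 to compound 4 (within the scatter), within the scatter.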

Compound 4, half-maximal inhibitory concentration: > 200000 nM
Compound 4 ended at the assay's limit; the forecaster's own chance of this, stated with the estimate: 50%; middle value at least 1.3-fold (0.12 log units) from the limit.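

Moving from a sulfur-linked to an oxygen-linked group at this saturated chain carbon bound to a carbonyl carbon, with (isoquinolin-3-yl)oxy entering, gives in this assay an at least 1.3-fold higher number from compound 3 to compound 4 (0.12 log units; that floor lies within the scatter), so no real loss is shown. Compound 4 gives > 200000 nM, which is a limit of the assay and not a number. Its steps from compound 1 and compound 2 join two limits and cannot be read.

On these data alone, whether a phenoxy group or an amine at this place would shift the number beyond the scatter stays open. Ranking these compounds also stays open, as most values stop at one ceiling: the limit of > 200000 nM in this assay, at which 3 of the 4 values shown sit.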